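The source may report more compounds than this note shows. Statements on the series, on what has been measured and on what is new or still open speak of the compounds shown alone.

Compound 1 `O=C(NCc1cn(Cc2ccc(F)cc2)nn1)c1cn(-c2ccccc2)nc1-c1ccccc1` gives 9600 nM in a functional assay on MIA PaCa-2 cells (Homo sapiens) for antiproliferative activity, read by sulforhodamine B assay, with a stated time of 48 h; on this read-out lower numbers stand for stronger inhibition of growth and higher numbers for weaker inhibition of growth. Compound 2 `COc1cc(Cn2cc(CNC(=O)c3cn(-c4ccccc4)nc3-c3ccccc3)nn2)cc(OC)c1` gives 190 nM. Compound 3 `COc1cc(Cn2cc(CNC(=O)c3cn(-c4ccccc4)nc3-c3ccccc3)nn2)cc(OC)c1OC` gives 1000 nM.

In this assay compound 3 holds the second highest of the three numbers: compound 2 is its nearest neighbour, separated by a 5.3-fold higher number from compound 2 to compound 3 (0.72 log units; beyond the scatter), while compound 1 lies furthest away, with a 9.6-fold lower number from compound 1 to compound 3 (0.98 log units; beyond the scatter).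

Compound 4 `COc1cc(Cn2cc(CNC(=O)c3cn(-c4ccccc4)nc3-c3ccc(Cl)cc3)nn2)cc(OC)c1OC` differs from compound 3 by chloro in place of hydrogen on an aromatic carbon, on an aromatic carbon of a six-membered aromatic ring of carbon only, para to a large group; cut one bond further out, phenyl becomes 4-chlorophenyl. Going by the values given here, none of the measured steps touches this ring: a 51-fold lower number from compound 1 to compound 2 (1.70 log units; beyond the scatter) and a 9.6-fold lower number from compound 1 to compound 3 (0.98 log units; beyond the scatter) exchange the aryl on the saturated chain carbon bound to an aromatic nitrogen, and a 5.3-fold higher number from compound 2 to compound 3 (0.72 log units; beyond the scatter) adds a methoxy there. Among the compounds with values here, no measured step bears on the chloro change, so no movement beyond the scatter is expected in this assay. Compound 4 is therefore expected to give about 1000 nM, within 300 nM to 3500 nM, meaning an expected no change at the digits printed from compound 3 to compound 4 (within the scatter).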

Compound 4, concentration for 50% growth inhibition: 3500 nM
Estimate against measurement, compound 4: 3.5-fold (0.54 log units) below, within the range that was stated.
By their numbers in this assay, from the lowest: compound 2; then compound 3; then compound 4; then compound 1.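

The earlier steps shown here changed only the aryl on the saturated chain carbon, whereas this one shows that the phenyl changed here to 4-chlorophenyl also affects the read-out in this assay. Chloro in place of hydrogen, para to a large group, gives a 3.5-fold higher number from compound 3 to compound 4 (0.54 log units; beyond the scatter), so this position does not tolerate the change without a measurable weakening of growth inhibition. No measurement available here accounts for this shift.

Going by these compounds, whether a methoxy or an amine at this position would move the number in the same direction remains open. So does whether chloro would have a similar effect on compound 2.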